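Working notes: 4-methylphenyl to 4-chlorophenyl

A few compounds are considered here, and "the series" means these few. Any claim that something is new, unique, unknown or untested is made for them only; others in the source may bear on it.

Of the compounds shown here, two have numbers so far in an ADME assay on THP-1 cells (Homo sapiens) for cytotoxicity, read by flow cytometry and propidium iodide staining, with a stated time of 72 h; on this read-out higher numbers stand for weaker inhibition and lower numbers for stronger inhibition. Compound 1 `Cn1cnc(CS(=O)(=O)c2ccc(Cl)cc2)c1[N+](=O)[O-]` gives 174000 nM, and compound 2 `Cc1ccc(S(=O)(=O)Cc2nc(C)n(C)c2[N+](=O)[O-])cc1` gives 242000 nM. These two values lie within the usual scatter of each other, so compound 2 stands level with compound 1 and the pair cannot be ranked.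

Compound 3 `Cc1nc(CS(=O)(=O)c2ccc(Cl)cc2)c([N+](=O)[O-])n1C` is still unmeasured in this assay. Its structure departs from that of compound 2 by a single change, chloro in place of methyl on an aromatic carbon, which turns the 4-methylphenyl into 4-chlorophenyl.

Within the data shown here, no measured pair in this small set isolates a single change, so the size of this step has no direct precedent. Among the measured compounds shown here, the only guide is how close the numbers are, with compound 1 at 174000 nM and compound 2 at 242000 nM.

No shift beyond the scatter is expected, and the estimated change is a 1.3-fold lower number from compound 2 to compound 3 (0.11 log units; within the scatter). For compound 3 the expected value is 190000 nM, with an estimated range from 100000 nM to 330000 nM.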

Compound 3, half-maximal inhibitory concentration: 68000 nM
For compound 3 the middle estimate is 2.8-fold (0.45 log units) above the measured one, outside the stated range (below it).
By their numbers in this assay, from the lowest: compound 3; then compounds 1 and 2 (each within the scatter of the next).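

Working notes on the result: in this assay, replacing 4-methylphenyl with 4-chlorophenyl, chloro in place of methyl on an aromatic carbon para to a large group, gives a 3.6-fold lower number from compound 2 to compound 3 (0.55 log units; beyond the scatter) and shows that this position can move the read-out beyond the scatter. The core can do so as well: with the 4-chlorophenyl kept, methyl in place of hydrogen on an aromatic carbon gives a 2.6-fold lower number from compound 1 to compound 3 (0.41 log units; beyond the scatter) as a second modest step, and both steps end at compound 3. No supporting data bear on why either step occurs.

It remains open whether the step belongs to chloro specifically, since the compounds shown carry only chloro and methyl at this position and give no reading for a group such as methoxy, an amine or a carboxylic acid there. It is also unclear whether the methyl step on the core would have the same size with 4-methylphenyl in place of 4-chlorophenyl, and compound 1 and compound 2 cannot settle this as they differ in two places.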